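Benzyl aryl swap on the three-carbon linker sulfonamides

The compounds below may be only part of what the source reports. "The series", "measured", "known", "first", "only" and "open" are said of these compounds alone.

Compound 2 `O=S(=O)(NCCCNCc1ccccc1Cl)c1cc(C(F)(F)F)cc(C(F)(F)F)c1` carries a 2-chlorobenzyl group on a three-carbon chain between the two amine nitrogens. In a functional assay on BE(2)-C cells (Homo sapiens) for inhibition, read by MTT assay, with a stated time of 72 h (on this read-out lower numbers stand for stronger inhibition of growth and higher numbers for weaker inhibition of growth), compound 2 gives 15000 nM. Of the three measured compounds it sits in the middle of a narrow spread: compound 1 `O=S(=O)(NCCNCc1cccc2ccccc12)c1cc(C(F)(F)F)cc(C(F)(F)F)c1`, with the shorter two-carbon chain and a naphthylmethyl group, gives 19000 nM in this assay, and compound 3 `O=S(=O)(NCCCNCc1ccc(Cl)c(C(F)(F)F)c1)c1cc(C(F)(F)F)cc(C(F)(F)F)c1` gives 8600 nM in this assay. For the measured compounds named here, the only single-point step, a 1.7-fold lower number from compound 2 to compound 3 (0.24 log units; within the scatter), concerns the same benzyl aryl ring that is varied here and stays inside the scatter.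

Compound 4 `O=S(=O)(NCCCNCc1ccc(C(F)(F)F)cc1)c1cc(C(F)(F)F)cc(C(F)(F)F)c1` differs from compound 2 by 4-(trifluoromethyl)phenyl in place of 2-chlorophenyl on a saturated chain carbon bound to an amine nitrogen. Going by the values given here, the one step that bears on this change is the aryl swap from compound 2 to compound 3, which also replaced the 2-chlorophenyl and moved the number only slightly downward, within the scatter. On that basis the expectation for compound 4 is a small step, if any, in the same direction: a 1.3-fold lower number from compound 2 to compound 4 (0.10 log units; within the scatter) is expected to remain within the scatter. The estimated value for compound 4 in this assay is 12000 nM, with a range from 5000 nM to 30000 nM.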

Compound 4, concentration for 50% growth inhibition: 2700 nM
Beside the measured number, compound 4's estimate is 4.4-fold (0.65 log units) above it; the measured number lies below the stated range.
By their numbers in this assay, from the lowest: compound 4; then compounds 3, 2 and 1 (each within the scatter of the next, the first and the last beyond it).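

Notes on the benzyl aryl group: in this assay, a 5.6-fold lower number from compound 2 to compound 4 (0.74 log units; beyond the scatter) is the first step at this position to clear the scatter, so the aryl group on the saturated chain carbon bound to an amine nitrogen does affect the read-out in this three-carbon series. A trifluoromethyl group on the ring is not enough on its own, since compound 3 also carries one and stays within the scatter of compound 2, while a 3.2-fold lower number from compound 3 to compound 4 (0.50 log units; beyond the scatter) separates the 4-(trifluoromethyl)phenyl ring from the 4-chloro-3-(trifluoromethyl)phenyl ring. Nothing among the data shown accounts for the size of either step.

The swap from compound 2 to compound 4 changes both the ring substituent and its place on the ring, so these compounds cannot assign the step to either change alone. Also open, from the compounds shown here alone, are whether a nitrile or a methoxy group in place of the trifluoromethyl group of the 4-(trifluoromethyl)benzyl unit would keep the lower number, and whether that unit would hold it on a longer chain.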